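The source may hold more compounds than are shown below. What is called first, only, known or untested is meant among the compounds shown, and "the series" means these compounds.

Measured so far:
compound 1, `Cc1cccc(Nc2nc(SCc3cn(Cc4ccccc4Cl)nn3)nc(-c3ccccc3)c2C#N)c1`: 19600 nM
compound 2, `Cc1ccccc1Nc1nc(SCc2cn(Cc3ccc(Cl)cc3)nn2)nc(-c2ccccc2)c1C#N`: > 64000 nM

Among the compounds with values here, in a functional assay on MCF7 cells (Homo sapiens) for inhibition, read by MTT assay, with a stated time of 72 h (on this read-out higher numbers stand for weaker inhibition and lower numbers for stronger inhibition), compound 1 gives 19600 nM, the only number among the two values shown. Compound 2 gives > 64000 nM, which is a limit of this assay and not a number; compound 2 sits at the limit of > 64000 nM in this assay, at which 1 of the 2 values shown sits. Compounds 1 and 2 differ in more than one place, so their two values are only set side by side here, without a step between them.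

Compound 3, `Cc1ccc(Nc2nc(SCc3cn(Cc4ccccc4Cl)nn3)nc(-c3ccccc3)c2C#N)cc1`, is not yet measured in this assay. It differs from compound 1 by 4-methylphenyl in place of 3-methylphenyl on a nitrogen on an aromatic ring. Within the data shown here, no measured step of this kind stands, so the size and direction of the change are open. Among the measured compounds shown here, with no comparable step to lean on, the step from compound 1 to compound 3 is expected to stay within the usual scatter, as a 1.0-fold higher number from compound 1 to compound 3 (0.01 log units; within the scatter). Compound 3 is therefore estimated at 20000 nM, within a range of 7000 nM to 60000 nM.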

Compound 3, half-maximal inhibitory concentration: 9420 nM
For compound 3 the middle estimate is 2.1-fold (0.33 log units) above the measured one; the range from low to high includes it.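

Replacing 3-methylphenyl with 4-methylphenyl on a nitrogen on an aromatic ring gives the series its first readable step at this position. In this assay, the step reads a 2.1-fold lower number from compound 1 to compound 3 (0.32 log units; beyond the scatter), so a change that leaves the atoms the same and only joins them differently is enough to move the number beyond the scatter, though only modestly, and compound 3 still stands at 9420 nM. Nothing shown gives a cause for this step, and the limit on compound 2 does not bear on it.

This single pair cannot show whether moving a group around this phenyl ring has a general effect on the series. Going by these compounds, how a 4-methoxyphenyl, a 4-chlorophenyl or a cyclohexyl on the same nitrogen would compare with 4-methylphenyl remains open.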